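Chain-end variation on the acetylphenol ether series

The source may report more compounds than this note shows. Statements on the series, on what has been measured and on what is new or still open speak of the compounds shown alone.

Measured so far:
compound 1 `CCc1cc(C(C)=O)c(O)cc1OCCCCCCC#N`: 73%
compound 2 `CCc1cc(C(C)=O)c(O)cc1OCCCCCCSC`: 14%

In an assay on isolated protein for binding affinity to leukotriene B4 receptor 1 (Homo sapiens), tested at 1 uM (on this read-out lower numbers stand for less inhibition and higher numbers for more inhibition at the one concentration tested (going by the name of the read-out)), compound 1 gives 73% and compound 2 gives 14%. Within the data shown here, the one measured step, a number 59 percentage points lower from compound 1 to compound 2 (beyond the scatter), shows that the group at the far end of the chain matters a great deal on this read-out. Compound 2 stands lowest of the two numbers; its nearest neighbour is compound 1, which sits far above it, beyond the scatter.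

Compound 3 `CCc1cc(C(C)=O)c(O)cc1OCCCCc1nnn[nH]1` is not yet measured. Relative to compound 2 the change is 1H-tetrazol-5-yl in place of 2-(methylsulfanyl)ethyl on a saturated chain carbon, four bonds along the chain from an oxygen on an aromatic ring. The chain is shortened and a ring with several hetero atoms takes the place of the methylsulfanyl end. The step from compound 1 to compound 2 bears on this only loosely, since no listed compound carries a tetrazolyl end or a chain of this length, but it shows that replacing the chain end can move the number by a large amount. Given that compound 2 is the lower of the two and that compound 1 with a nitrogen-bearing end gives 73%, a rise is expected in this assay, a number 36 percentage points higher from compound 2 to compound 3 (beyond the scatter). Compound 3 is therefore estimated at 50%, with a wide range from 15% to 85%.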

Compound 3, a percentage reported as inhibition, at one concentration (the size of the read-out at that concentration, not a potency): 19%
Compound 3: middle estimate off by 31 percentage points, on the high side; the measured number falls inside the stated range.
By their numbers in this assay, from the lowest: compounds 2 and 3 (each within the scatter of the next); then compound 1.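

Working notes on the chain end: in this assay, the tetrazolyl end does not lift the number away from the methylsulfanyl end, with a number 5 percentage points higher from compound 2 to compound 3 (within the scatter) as the printed step, so compound 2 and compound 3 cannot be told apart despite their very different chain ends. The comparison with the nitrile gives a number 54 percentage points lower from compound 1 to compound 3 (beyond the scatter) as its step, which leaves compound 1 alone above the other two and shows that a nitrogen-rich ring at this place does not carry the level of the nitrile-ended compound. Nothing in hand explains either step, and the data give no independent measurement that bears on them.

Both steps to compound 3 change the length of the chain together with its end group, so the compounds shown do not separate the two contributions, and it remains open whether the nitrile would hold its number on the shorter chain or the 1H-tetrazol-5-yl group would gain on the longer one. A carboxylic acid or a primary amide at the chain end, on either chain length, would show whether the nitrile stands alone among such ends.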